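The compounds below may be only part of what the source reports. "The series", "measured", "known", "first", "only" and "open" are said of these compounds alone.

Working notes on the series. Of the compounds shown here, two have been measured in an assay on L cells for inhibition of Protein-serine O-palmitoleoyltransferase porcupine (Mus musculus), read by reporter gene assay, with a stated time of 24 h; a lower number here means that less compound is needed, a higher number that more compound is needed for the effect. Compound 1, `O=C(CNC(=O)c1nn(-c2ccc(F)cc2)c(=O)c2ccccc12)Nc1nc2ccccc2s1`, returns only a limit of the assay: in this assay compound 1 gives > 25000 nM. Compound 2, `O=C(CSc1nc2c(c(=O)n1-c1ccccc1)SCC2)Nc1ccc(N2CCCCC2)cc1`, is built on a different core; in this assay compound 2 gives 30 nM. Within the data shown here, no step between two compounds of one core has been measured, so the two values show only that compound 2 sits at a number while compound 1 sits at the limit of > 25000 nM in this assay, at which 1 of the 2 values shown sits.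

Compound 3, `COc1ccccc1-n1nc(C(=O)NCC(=O)Nc2nc3ccccc3s2)c2ccccc2c1=O`, keeps the core of compound 1 and differs from it in one place: 2-methoxyphenyl in place of 4-fluorophenyl on an aromatic nitrogen. Nothing measured within this core tells how the group on the aromatic nitrogen moves the read-out. Compound 1 stands at the limit, and no step beyond the scatter is expected in either direction, so the chance that compound 3 again returns only a limit is taken as high. The estimate for compound 3 in this assay is 25000 nM, with a range from 6000 nM to 60000 nM. The expected step from compound 1 to compound 3 is a number no higher from compound 1 to compound 3 (the limit leaves the size open), that is none beyond the scatter.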

Compound 3, half-maximal effective concentration: 10000 nM
The estimate for compound 3 lay 2.5-fold (0.40 log units) above the measured number, and the stated range covers the measured number.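

In this assay, 2-methoxyphenyl in place of 4-fluorophenyl on the aromatic nitrogen gives an at least 2.5-fold lower number from compound 1 to compound 3 (0.39 log units; beyond the scatter). Among these compounds, this is the first measured step within the core of compound 1, and it shows that the group at this position can move the read-out, with compound 3 giving a number on this core rather than a limit. Compound 1 stands at a limit of the assay and not at a number, so the step has a lower bound but no known size: the limit of > 25000 nM in this assay, at which 1 of the 3 values shown sits.

This single change removes the fluorine and brings in the methoxy group together, so the compounds shown cannot separate the contribution of one from the other, or tell whether the step depends on the group's identity or on where it sits on the phenyl ring. Also open, from the compounds shown here alone, is how the read-out would respond to a plain phenyl, a 2-ethoxyphenyl or a pyridine ring at this nitrogen, and whether any of these would carry the number further down than compound 3 does.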